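Pentyl in place of phenylethyl on the urea nitrogen

The compounds below may be only part of what the source reports. "The series", "measured", "known", "first", "only" and "open" are said of these compounds alone.

Compound 1 `Cc1nc(N)sc1CCCN/C(N)=N/C(=O)N[C@@H](C)c1ccccc1` — 23.4 nM
Compound 2 `Cc1nc(N)sc1CCCN/C(N)=N/C(=O)NC(c1ccccc1)C(C)C` — 34.7 nM

In a functional assay on Right cardiac atrium for agonist activity at histamine H2 receptor (Cavia porcellus), with a stated time of 30 min, in the presence of a further agent that is not named here (a lower number here means that less compound is needed, a higher number that more compound is needed for the effect), compound 1 gives 23.4 nM and compound 2 gives 34.7 nM; the two numbers lie within the scatter of each other, so neither can be placed above the other. Compound 1 has the lower of the two numbers as measured, but nothing more is claimed from that. Compound 3 `CCCCCNC(=O)/N=C(\N)NCCCc1sc(N)nc1C` has not yet been measured in this assay. It differs from compound 1 in one place: pentyl in place of 1-phenylethyl on an amide-type nitrogen. Among the measured compounds shown here, since no step between measured compounds covers a change of this kind, the expectation rests on the two numbers alone. Compound 3 is expected to need somewhat more compound than compound 1, a step of a 2.4-fold higher number from compound 1 to compound 3 (0.37 log units; beyond the scatter), with a fair chance that it stays within the scatter. Compound 3 is therefore estimated at 55 nM, in a range from 15 nM to 200 nM.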

Compound 3, half-maximal effective concentration: 5.75 nM
Beside the measured number, compound 3's estimate is 9.6-fold (0.98 log units) above it, outside the stated range (below it).
By their numbers in this assay, from the lowest: compound 3; then compounds 1 and 2 (each within the scatter of the next).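

Pentyl in place of 1-phenylethyl on the amide-type nitrogen gives a 4.1-fold lower number from compound 1 to compound 3 (0.61 log units; beyond the scatter) in this assay and so shows that neither a six-membered aromatic ring nor a defined stereocentre in this group is needed for a low number. Compounds 1 and 2 both carry an aromatic ring here and their values lie within the scatter of each other, so only compound 3 shows that a change at this place can move the number beyond the scatter.

On these data alone, it remains open whether a butyl group or a longer chain such as hexyl would lower the number further or raise it again. Also open, as far as these compounds go, is how a chain ending in an amine or a carboxylic acid, or a saturated ring such as cyclohexyl, would fare at this place.

No measurement at hand accounts for the size or direction of this step.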